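Oxygen to sulfur swap at the three-position of the aryl ring

The source may hold more compounds than are shown below. What is called first, only, known or untested is meant among the compounds shown, and "the series" means these compounds.

In an assay on HeLa cells for displacement of a labelled ligand from adenosine receptor A3 (Homo sapiens), with a stated time of 180 min, tested at 10 uM (on this read-out lower numbers stand for less inhibition and higher numbers for more inhibition at the one concentration tested (going by the name of the read-out)), compound 1 `CCOC(=O)C1=C(C)N(C)C(=O)NC1c1ccco1` gives 25%, compound 2 `CCOC(=O)C1=C(C)N(C)C(=O)NC1c1cccs1` gives 6% and compound 3 `CCOC(=O)C1=C(C)N(C)C(=O)NC1c1ccoc1` gives 1%. Compound 3 stands lowest of the three, separated from compound 1 by a number 24 percentage points lower from compound 1 to compound 3 (beyond the scatter), while the gap a number 5 percentage points lower from compound 2 to compound 3 (within the scatter) is within the scatter. Compound 4 `CCOC(=O)C1=C(C)N(C)C(=O)NC1c1ccsc1` differs from compound 3 by thiophen-3-yl in place of furan-3-yl on a saturated ring carbon. The closest measured analogy is the oxygen to sulfur change at the two-position, a number 19 percentage points lower from compound 1 to compound 2 (beyond the scatter), which lowered the read-out; compound 3 already sits near the floor, so no step beyond the scatter in this assay is expected. For compound 4 the estimate is 3%, range 0% to 15%, meaning an expected step of a number 2 percentage points higher from compound 3 to compound 4 (within the scatter).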

Compound 4, a percentage reported as inhibition, at one concentration (the size of the read-out at that concentration, not a potency): 3%
For compound 4 middle estimate and measured number coincide at the digits printed; the measured number falls inside the stated range.
By their numbers in this assay, from the lowest: compounds 3, 4 and 2 (each within the scatter of the next); then compound 1.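

In this assay, thiophen-3-yl and furan-3-yl on this saturated ring carbon cannot be told apart (a number 2 percentage points higher from compound 3 to compound 4 (within the scatter)), and neither can thiophen-3-yl and thiophen-2-yl (a number 3 percentage points lower from compound 2 to compound 4 (within the scatter)). Furan-2-yl alone stands clear of the new compound (a number 22 percentage points lower from compound 1 to compound 4 (beyond the scatter)), so in these four compounds only compound 1 separates from the rest. No measurement available here explains this.

Open, going by these compounds, is whether a phenyl or pyridyl ring at this carbon would exceed furan-2-yl. Also open, on these data alone, is whether the separation of furan-2-yl persists with a carboxylic acid replacing the ethoxycarbonyl group.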